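Trimethoxyphenyl amide series: benzyl methoxy to chloro

This account rests on a few compounds, and the source may have more. Where it says the series, first, only, none or still open, it means among the compounds named here.

Compound 1 `COc1ccc(CN(C(=O)CSC(=S)N2CCN(C(=O)OC(C)(C)C)CC2)c2cc(OC)c(OC)c(OC)c2)cc1` is the reference of this small set. Within the data shown here, in a functional assay on MGC-803 cells (Homo sapiens) for inhibition, read by CCK-8 assay, with a stated time of 48 h (on this read-out higher numbers stand for weaker inhibition and lower numbers for stronger inhibition), compound 1 gives 310 nM, the only number in the set. Compound 2 `COc1ccc(CN(C(=O)CSC(=S)N2CCN(C(=O)OC(C)(C)C)CC2)c2ccc(Cl)cc2)cc1` reaches only a limit of the assay, > 20000 nM. Compound 3 `COc1ccc(CN(C(=O)CSC(=S)N2CCN(C(=O)OC(C)(C)C)CC2)c2ccc(OC)cc2)cc1` likewise sits at a limit, > 20000 nM. The core difference, (3,4,5-trimethoxyphenyl in place of 4-methoxyphenyl on an amide-type nitrogen), corresponds in this assay to an at least 64-fold higher number from compound 1 to compound 3 (1.80 log units; beyond the scatter), read in the reverse direction; replacing the 3,4,5-trimethoxyphenyl by 4-chlorophenyl gives an at least 64-fold higher number from compound 1 to compound 2 (1.80 log units; beyond the scatter). The change chloro in place of methoxy on an aromatic carbon yields a step that the two limits leave unreadable from compound 3 to compound 2, since both values meet (the limit of > 20000 nM in this assay, at which 2 of the 3 values shown sit). Compound 4 `COc1cc(N(Cc2ccc(Cl)cc2)C(=O)CSC(=S)N2CCN(C(=O)OC(C)(C)C)CC2)cc(OC)c1OC` carries the same change, (chloro in place of methoxy on an aromatic carbon), though cut one bond further out it reads 4-methoxybenzyl to 4-chlorobenzyl, on the benzyl side rather than the amide-type nitrogen aryl. With the 3,4,5-trimethoxyphenyl retained, only a modest step is expected, a 1.6-fold higher number from compound 1 to compound 4 (0.21 log units; within the scatter), resting on compound 1 at 310 nM. Compound 4 is estimated at 500 nM, between 120 nM and 3000 nM.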

Compound 4, half-maximal inhibitory concentration: 12900 nM
Estimate against measurement, compound 4: 26-fold (1.41 log units) below; the whole stated range lies below it.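

In this assay, 4-methoxybenzyl to 4-chlorobenzyl with the 3,4,5-trimethoxyphenyl retained gives a 42-fold higher number from compound 1 to compound 4 (1.62 log units; beyond the scatter), so on the core of compound 1 this single exchange is far from neutral. Among these compounds, the chloro in place of methoxy change on the other aromatic ring, from compound 3 to compound 2, cannot be read, since both compounds stand at a limit: the limit of > 20000 nM in this assay, at which 2 of the 4 values shown sit. Whether the step carries to another core therefore remains unshown, as the series offers only this one readable instance.

Open, on these data alone, is whether the step follows chloro specifically or the departure of methoxy. Fluoro, methyl, hydroxy or a dimethylamino group at the same place on the benzyl ring would separate these readings.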